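A few compounds are considered here, and "the series" means these few. Any claim that something is new, unique, unknown or untested is made for them only; others in the source may bear on it.

The study reads growth inhibition in a functional assay on A549 cells (Homo sapiens) for antiproliferative activity, read by sulforhodamine B assay, with a stated time of 72 h; on this read-out lower numbers stand for stronger inhibition of growth and higher numbers for weaker inhibition of growth. Compound 1 `CCc1cc(=O)c2ccc(Sc3cccc(Cl)[n+]3[O-])cc2o1` reaches only a limit there, > 29900 nM. Compound 2 `CCOc1ccc2c(=O)cc(CC)oc2c1CBr` likewise gives only a limit in this assay, > 32100 nM. Going by the values given here, compound 3 `CCOc1ccc2c(=O)cc(C(C)Br)oc2c1CBr` is the sole compound with an actual number in this assay, where compound 3 gives 19800 nM. The two other values shown are limits rather than numbers. One of them is recorded as the limit of > 29900 nM in this assay, at which 1 of the 3 values shown sits. The other is recorded as the limit of > 32100 nM in this assay, at which 1 of the 3 values shown sits. Among the compounds with values here, the only step between measured compounds, an at least 1.6-fold lower number from compound 2 to compound 3 (0.20 log units; that floor lies within the scatter), concerns a different part of the molecule and is itself no larger than the scatter.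

Compound 4 `CC(C)COc1ccc2c(=O)cc(C(C)Br)oc2c1CBr` differs from compound 3 by isopropyl in place of methyl on a saturated chain carbon bound to an oxygen on an aromatic ring. Within the data shown here, no measured step touches this chain, so the measured compounds give no direction for it, and the expected step is a 1.0-fold higher number from compound 3 to compound 4 (0.00 log units; within the scatter), nothing beyond the scatter. In this assay compound 4 is therefore expected to give 20000 nM, estimated to lie between 7000 nM and 60000 nM.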

Compound 4, concentration for 50% growth inhibition: 8710 nM
The estimate for compound 4 lay 2.3-fold (0.36 log units) above the measured number; low and high end bracket the measured number.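

In this assay, the change from ethoxy to isobutoxy gives a 2.3-fold lower number from compound 3 to compound 4 (0.36 log units; beyond the scatter), which makes this chain on the oxygen the only place among the compounds shown where a single change moves the read-out beyond the scatter. The earlier step, an at least 1.6-fold lower number from compound 2 to compound 3 (0.20 log units; that floor lies within the scatter), concerned a different part of the molecule, stayed within the scatter and said nothing about this chain. The step here is modest, and no measurement shown accounts for it.

On these data alone, only ethoxy and isobutoxy can be compared at this place, so it stays open whether a longer chain, a benzyloxy group or a chain ending in an amine would lower the number further or raise it again. As far as these compounds go, it also stays open whether the isobutoxy step would hold without the bromo on the saturated chain carbon.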